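The source may report more compounds than this note shows. Statements on the series, on what has been measured and on what is new or still open speak of the compounds shown alone.

Measured so far:
compound 1 `COc1cc(OC)c(-c2coc3cc(OCc4ccc(C#N)cc4)ccc3c2=O)cc1OC` — 1550 nM in a functional assay on A-375 cells (Homo sapiens) for antiproliferative activity, read by MTT assay, with a stated time of 24 h; a higher number here means a weaker inhibitor, a lower number a stronger inhibitor
compound 2 `COc1cc(OC)c(-c2coc3cc(OCc4ccccc4C#N)ccc3c2=O)cc1OC` — 990 nM

Compound 2 gives the lowest of the two numbers, but the step of a 1.6-fold lower number from compound 1 to compound 2 (0.19 log units; within the scatter) is within the scatter, so the two compounds stand level. Compound 3 `COc1cc(OC)c(-c2coc3cc(OCc4ccc(C(F)(F)F)cc4)ccc3c2=O)cc1OC` is unmeasured; it differs from compound 2 by 4-(trifluoromethyl)phenyl in place of 2-cyanophenyl on a saturated chain carbon bound to an oxygen on an aromatic ring. Among the compounds with values here, the only measured step, which shifts a nitrile on the phenyl ring, is within the scatter, and no step bears on a trifluoromethyl group. No step beyond the scatter is therefore expected, a 1.2-fold higher number from compound 2 to compound 3 (0.08 log units; within the scatter). Compound 3 is estimated at 1200 nM, range 500 nM to 3000 nM.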

Compound 3, half-maximal inhibitory concentration: 2280 nM
Estimate against measurement, compound 3: 1.9-fold (0.28 log units) below, and the stated range covers the measured number.
By their numbers in this assay, from the lowest: compounds 2, 1 and 3 (each within the scatter of the next, the first and the last beyond it).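

In this assay this position gives its first step beyond the scatter, though only a modest one: a 2.3-fold higher number from compound 2 to compound 3 (0.36 log units; beyond the scatter) for 4-(trifluoromethyl)phenyl in place of 2-cyanophenyl. Trifluoromethyl in place of cyano on an aromatic carbon stays within the scatter at a 1.5-fold higher number from compound 1 to compound 3 (0.17 log units; within the scatter) so the exchange of these two groups does not by itself separate the compounds. Nothing measured here accounts for either step. Still open, as far as these compounds go, is how an amine or a carboxylic acid on the phenyl ring would read in this assay. From the compounds shown here alone, a longer chain in place of the benzyl link is equally open.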